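Swapping the amide aryl group on a bis-indole nitrile core

The source may report more compounds than this note shows. Statements on the series, on what has been measured and on what is new or still open speak of the compounds shown alone.

Measured so far:
- compound 1, `CN1[C@@H]2c3[nH]c4ccccc4c3C[C@H]1[C@H](C#N)N1[C@@H](CN3C(=O)c4ccccc4C3=O)c3[nH]c4ccccc4c3C[C@@H]21`: 80 nM
- compound 2, `CN1[C@@H]2c3[nH]c4ccccc4c3C[C@H]1[C@H](C#N)N1[C@@H](CNC(=O)c3cccc4c3CCCC4)c3[nH]c4ccccc4c3C[C@@H]21`: 810 nM
- compound 3, `CN1[C@@H]2c3[nH]c4ccccc4c3C[C@H]1[C@H](C#N)N1[C@@H](CNC(=O)c3ccc4ccccc4c3)c3[nH]c4ccccc4c3C[C@@H]21`: 1030 nM

All three compounds share one core and differ only in the group attached to the side-chain nitrogen. In a functional assay on A2780 cells (Homo sapiens) for cytotoxicity, read by MTT assay, with a stated time of 72 h (a lower number here means a stronger inhibitor, a higher number a weaker inhibitor), compound 1 gives 80 nM, compound 2 gives 810 nM and compound 3 gives 1030 nM. Compound 3 thus has the highest number of the three; its value and that of compound 2 lie within the scatter of each other, while compound 1 sits well apart.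

Compound 4, `COc1ccc(/C=C/C(=O)NC[C@H]2c3[nH]c4ccccc4c3C[C@H]3[C@H]4c5[nH]c6ccccc6c5C[C@@H]([C@H](C#N)N23)N4C)cc1`, has not yet been measured. It differs from compound 3 in one place: 2-(4-methoxyphenyl)ethenyl in place of naphthalen-2-yl on a carbonyl carbon.

Going by the values given here, the one measured step that resembles this change, an exchange of the aryl group on the same carbonyl carbon, is a 1.3-fold higher number from compound 2 to compound 3 (0.10 log units; within the scatter). Nothing here shows that a change of this kind moves the number far, so for compound 4 in this assay no step beyond the scatter is expected, with a 1.0-fold lower number from compound 3 to compound 4 (0.01 log units; within the scatter) as the expected step. Compound 4 is therefore estimated at 1000 nM, with a range from 400 nM to 2500 nM.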

Compound 4, half-maximal inhibitory concentration: 860 nM
Compound 4: middle estimate off by 1.2-fold (0.07 log units), on the high side, and the stated range covers the measured number.
By their numbers in this assay, from the lowest: compound 1; then compounds 2, 4 and 3 (each within the scatter of the next).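

In this assay, the naphthalen-2-yl group on this carbonyl carbon can give way to a differently built group without a step beyond the scatter (a 1.2-fold lower number from compound 3 to compound 4 (0.08 log units; within the scatter)), and the same holds against the 1,2,3,4-tetrahydronaphthalen-5-yl group (a 1.1-fold higher number from compound 2 to compound 4 (0.03 log units; within the scatter)). Going by these compounds alone, the entering 2-(4-methoxyphenyl)ethenyl group has only one aromatic ring, a double bond outside that ring and an oxygen atom, so this position now holds three different groups whose numbers this assay does not separate. No measurement is available that explains this result.

The compounds shown leave open whether the double bond matters, which the saturated 2-(4-methoxyphenyl)ethyl group could test. They also leave open whether a small methyl group or a chain ending in an amine on this carbonyl carbon would move the number beyond the scatter.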